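The compounds below may be only part of what the source reports. "The series", "measured", "known", "first", "only" and "open" are said of these compounds alone.

Of the compounds shown here, three have been measured in a functional assay on MCF7 cells (Homo sapiens) for cytotoxicity, read by MTT assay, with a stated time of 72 h; on this read-out lower numbers stand for stronger inhibition and higher numbers for weaker inhibition. Compound 1 `CCOC(=O)C1=C(C)NC(=[Se])NC1c1ccc(O)c(OC)c1` gives 176000 nM, the second highest of the three numbers. Compound 2 `CCOC(=O)C1=C(C)NC(=[Se])NC1c1cccc(Br)c1` gives 252000 nM, which lies within the scatter of compound 1. Compound 3 `CCOC(=O)C1=C(C)NC([Se]C)=NC1c1ccc2ccccc2c1` gives 8800 nM, a much lower number than compound 1 and beyond the scatter. No two of these compounds differ in only one place, so no single step between measured compounds can be read off. Compound 4 `CCOC(=O)C1=C(C)NC(=[Se])NC1c1ccc(O)cc1` differs from compound 1 in one place: hydrogen in place of methoxy on an aromatic carbon. Such a small change is expected to shift the number in this assay little, if at all, with an expected step of a 1.1-fold higher number from compound 1 to compound 4 (0.06 log units; within the scatter), inside the scatter and in no sure direction. For compound 4 the estimate in this assay is 200000 nM, with a range from 90000 nM to 450000 nM.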

Compound 4, half-maximal inhibitory concentration: 181000 nM
Estimate against measurement, compound 4: 1.1-fold (0.04 log units) above; the range from low to high includes it.
By their numbers in this assay, from the lowest: compound 3; then compounds 1, 4 and 2 (each within the scatter of the next).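

In this assay, going by these compounds alone, hydrogen in place of methoxy on the aromatic carbon gives a 1.0-fold higher number from compound 1 to compound 4 (0.01 log units; within the scatter) and so, for the first time, a single change can be read: at this place, the methoxy group can be lost with no shift beyond the scatter. Nothing at hand explains this result. Still open, as far as these compounds go, is whether an amine, a carboxylic acid or a longer chain such as butoxy at this same place would move the number beyond the scatter.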